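The source may hold more compounds than are shown below. What is called first, only, known or untested is meant among the compounds shown, and "the series" means these compounds.

Of the compounds shown here, three have been measured so far in a toxicity assay on the whole organism (J774 cells) for cytotoxicity, with Mus musculus as the target, read by MTT assay, with a stated time of 24 h, tested at 10 uM; a higher number here means a weaker effect of the compound at the concentration tested, a lower number a stronger effect. Compound 1 `CCCCCCCCCO[C@@H]1[C@@H](N)[C@@H](OCC(O)CNCCO)O[C@H](CN)[C@H]1OCCCCCCCCC` gives 99.1% in this assay. Compound 2 `NC[C@H]1O[C@H](O[C@H]2[C@H](O)[C@@H](OCc3ccc4ccccc4c3)[C@H](N)C[C@@H]2N)[C@H](N)[C@@H](OCc2ccc3ccccc3c2)[C@@H]1O` gives 86%, and compound 3 `NC[C@H]1O[C@H](O[C@H]2[C@H](O)[C@@H](O)[C@H](N)C[C@@H]2N)[C@H](N)[C@@H](OCCCc2ccc3ccccc3c2)[C@@H]1OCCCc1ccc2ccccc2c1` gives 87.7%. Among these three, compound 1 stands highest, so its effect on the cells is the weakest of the set; its nearest neighbour is compound 3, and the gap to it lies beyond the usual scatter, as does the somewhat larger gap to compound 2.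

Compound 4 `CCCCCCCCCO[C@@H]1[C@@H](N)[C@@H](OC[C@@H](O)CN)O[C@H](CN)[C@H]1OCCCCCCCCC` has not yet been measured. It keeps the core of compound 1 and differs from it in one place: 2-amino-1-hydroxyethyl in place of 1-hydroxy-2-((2-hydroxyethyl)amino)ethyl on a saturated chain carbon bound to an oxygen on a saturated carbon. For the measured compounds named here, no measured pair shows what such a change does here, so the expectation rests only on how close compound 4 is to compound 1 and on the fact that all three measured numbers are high. The step of a number 6.1 percentage points lower from compound 1 to compound 4 (within the scatter) is expected to be small, pointing slightly downward, and not beyond the scatter. Compound 4 is therefore estimated at 93%, with a likely range from 78% to 100%.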

Compound 4, a percentage reported as activity, at one concentration (the size of the read-out at that concentration, not a potency): 85.1%
Estimate against measurement, compound 4: 7.9 percentage points above; the measured number falls inside the stated range.
By their numbers in this assay, from the lowest: compounds 4, 2 and 3 (each within the scatter of the next); then compound 1.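

For the compounds shown here, this is the first pair that differs in one place, and it shows that the group on a saturated chain carbon bound to an oxygen on a saturated carbon is not a neutral spot in this assay: 2-amino-1-hydroxyethyl in place of 1-hydroxy-2-((2-hydroxyethyl)amino)ethyl gives a number 14 percentage points lower from compound 1 to compound 4 (beyond the scatter). Since a lower number means a stronger effect on the cells, the smaller group, with 4 heavy atoms against 7, goes with more effect here, and it also brings a defined stereocentre. Nothing shown explains this step.

A single pair cannot separate the loss of the hydroxyethyl part from the defined stereocentre. From the compounds shown here alone, the effect of a guanidine or a longer 3-hydroxypropyl group on that nitrogen remains open.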